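Lengthening an Alkyl Chain on an Antiproliferative Triazene Core

The source may hold more compounds than are shown below. What is called first, only, known or untested is meant among the compounds shown, and "the series" means these compounds.

Compound 1, `CN(C)/N=N/c1n[nH]cc1C(N)=O`, gives 3.49 in a functional assay on L1210 cells (Mus musculus) for antiproliferative activity; a higher number here means a more potent compound, by a factor of ten per unit of this negative logarithm, a lower number a less potent compound.
Compound 2, `CCOC(=O)c1c[nH]nc1/N=N/N(C)C`, gives 3.35 in this assay.

Among the compounds with values here, compound 1 has the higher of the two numbers known so far, but its one neighbour, compound 2, sits close: the step of a number 0.14 log units lower from compound 1 to compound 2 (within the scatter) is within the scatter, so the two compounds cannot be told apart on this evidence. That step exchanges ethoxy for amino on a carbonyl carbon and leaves the rest of the molecule untouched.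

Compound 3, `CCCN(C)/N=N/c1n[nH]cc1C(N)=O`, has not been measured. It differs from compound 1 by ethyl in place of hydrogen on a saturated chain carbon bound to an amine nitrogen; seen one bond further out, the change reads methyl to propyl, dimethylamino to methyl(propyl)amino.

Within the data shown here, no measured step touches this part of the molecule, so nothing here tells how this assay responds to a longer chain on the amine nitrogen. Among the measured compounds shown here, with the only known step small, the plain expectation is a step of a number 0.01 log units higher from compound 1 to compound 3 (within the scatter) that does not exceed the scatter. Compound 3 is therefore estimated at 3.5, within a range from 3 to 4.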

Compound 3, logarithm of the reciprocal of the active concentration, log(1/C): 3.7
Compound 3: middle estimate off by 0.20 log units, on the low side; measured number inside the range.
By their numbers in this assay, from the lowest: compounds 2, 1 and 3 (each within the scatter of the next, the first and the last beyond it).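

Within the data shown here, this is the first measured change at the amine nitrogen, where methyl(propyl)amino replaces dimethylamino. In this assay the change gives a number 0.21 log units higher from compound 1 to compound 3 (within the scatter) and so cannot be told apart from repeat-to-repeat variation. The position therefore accepts ethyl in place of hydrogen on a saturated chain carbon bound to an amine nitrogen with no detectable loss, but this single step does not establish a gain; no measurement is available that would explain it.

Still open, on these data alone, is whether a butyl or hexyl chain on the same amine nitrogen would keep the number in this assay level or move it beyond the scatter, since one chain length cannot show a trend. It is also unknown whether the propyl chain would give a similar step when combined with ethoxy in place of amino on a carbonyl carbon, the change that separates compound 2 from compound 1.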